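Aryl methoxy to trifluoromethoxy swap on the shared core

This account rests on a few compounds, and the source may have more. Where it says the series, first, only, none or still open, it means among the compounds named here.

Measured in a functional assay on CHO cells for antagonist activity at corticotropin-releasing factor receptor 1 (Homo sapiens), read by cAMP accumulation; a higher number here means a weaker inhibitor, a lower number a stronger inhibitor:
compound 1 `COc1ccc(-n2ncc3c(NC(C4CC4)C4CC4)nc(C)nc32)c(C)c1` gives 32 nM
compound 2 `COc1ccc(-n2c(C)nc3c(NC(C4CC4)C4CC4)nc(C)nc32)cc1` gives 19 nM
compound 3 `COc1ccc(-n2c(C3CC(F)(F)C3)nc3c(NC(C4CC4)C4CC4)nc(C)nc32)cc1` gives 261 nM

Compound 2 holds the lowest number of the three in this assay; compound 1 sits within the scatter of it, while compound 3 lies well beyond. Among the measured compounds shown here, the only single-point step measured, a 14-fold higher number from compound 2 to compound 3 (1.14 log units; beyond the scatter), concerns the methyl on an aromatic carbon and not the methoxy group. Compound 4 `Cc1nc(NC(C2CC2)C2CC2)c2nc(C)n(-c3ccc(OC(F)(F)F)cc3)c2n1` differs from compound 2 by trifluoromethyl in place of methyl on an oxygen on an aromatic ring. For the measured compounds named here, no measured step touches the methoxy group, so nothing in the set bears directly on this change; the step from compound 2 to compound 3 shows only that a large loss occurred at a different position. Going by the values given here, with no comparable precedent, the expected step in this assay is small: a 1.6-fold higher number from compound 2 to compound 4 (0.20 log units; within the scatter) is the estimate, not beyond the scatter in either direction. Compound 4 is therefore expected to give 30 nM in this assay, with a range from 10 nM to 100 nM.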

Compound 4, inhibition constant: 9 nM
Estimate against measurement, compound 4: 3.3-fold (0.52 log units) above; measured number below the stated range.
By their numbers in this assay, from the lowest: compound 4; then compounds 2 and 1 (each within the scatter of the next); then compound 3.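

Replacing methyl on an oxygen on an aromatic ring with trifluoromethyl gives, in this assay, a 2.1-fold lower number from compound 2 to compound 4 (0.32 log units; beyond the scatter); this oxygen substituent therefore accepts the change without loss and gives a modest gain. Among the compounds shown here, the only other single-place step, a 14-fold higher number from compound 2 to compound 3 (1.14 log units; beyond the scatter), runs in the opposite direction at a different position, so the two sites respond differently to fluorine-bearing replacements in these two examples. No supporting measurement accounts for the lower number at this position.

Trifluoromethoxy appears here only on the core of compound 2, so whether the gain carries over to the cores of compound 1 or compound 3 remains open. Also open, as far as these compounds go, is how difluoromethyl, ethyl or a longer chain on the same oxygen would read, or a chlorine replacing the whole trifluoromethoxy group.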